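Diaryl ether thiosemicarbazones: lipophilicity notes, compound 3

The source may report more compounds than this note shows. Statements on the series, on what has been measured and on what is new or still open speak of the compounds shown alone.

Measured so far:
compound 1 `Cc1ccc(Oc2ccc(/C=N/NC(=S)Nc3ccc(F)cc3)cc2)cc1` — 5.48
compound 2 `Fc1ccc(NC(=S)N/N=C/c2ccc(Oc3ccc4ccccc4c3)cc2)cc1` — 6.2

Compound 2 stands highest of the two numbers in a physicochemical assay for lipophilicity, in phosphate buffer, measured as octanol-water partition, with a stated time of 24 h; on this read-out lower numbers stand for lower lipophilicity and higher numbers for higher lipophilicity; its nearest neighbour is compound 1, which in this assay gives 5.48, and the step of a number 0.72 log units higher from compound 1 to compound 2 (beyond the scatter) is beyond the scatter.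

Compound 3 `O=[N+]([O-])c1ccc(Oc2ccc(/C=N/NC(=S)Nc3ccc(F)cc3)cc2)cc1` is not yet measured. Its change from compound 2 is 4-nitrophenyl in place of naphthalen-2-yl on an oxygen on an aromatic ring.

For the measured compounds named here, only one measured step bears on this: the step of a number 0.72 log units higher from compound 1 to compound 2 (beyond the scatter), which shows that swapping the group on the oxygen moves the read-out by a modest amount. Going by the values given here, no step is available for a nitro group against a methyl group here, so the comparison of compound 3 with compound 1 rests on the structural change alone. Compound 3 is expected to fall back to a single six-membered ring on the oxygen, so a step downward from compound 2 is expected, a number 1.30 log units lower from compound 2 to compound 3 (beyond the scatter), of roughly the reverse size seen in the step of a number 0.72 log units higher from compound 1 to compound 2 (beyond the scatter) or somewhat larger. The estimate for compound 3 in this assay is 4.9, with a range from 4.4 to 5.5.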

Compound 3, partition coefficient: 4.89
Beside the measured number, compound 3's estimate is 0.01 log units above it; measured number inside the range.
By their numbers in this assay, from the lowest: compound 3; then compound 1; then compound 2.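

In this assay, the place on the oxygen now shows a downward move as well as an upward one: 4-nitrophenyl in place of naphthalen-2-yl gives a number 1.31 log units lower from compound 2 to compound 3 (beyond the scatter), a large step, and leaves compound 3 lowest of the three, with its steps to both others beyond the scatter. Nitro in place of methyl on an aromatic carbon gives a number 0.59 log units lower from compound 1 to compound 3 (beyond the scatter), a modest step, so the loss of the second aromatic ring of naphthalen-2-yl does not alone set the number, and the group carried on the remaining ring also counts among these three compounds. Nothing measured here gives a reason for either step.

The compounds shown leave open where an amine or a carboxylic acid in the place of the nitro group would fall relative to these three values, and whether a longer chain in the place of the methyl group would raise the number further. They also leave open whether the order of the three groups on the oxygen holds once the fluorine of the shared core gives way to chlorine.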